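The compounds below may be only part of what the source reports. "The series", "measured", "known", "first", "only" and "open" are said of these compounds alone.

Measured so far in a functional assay on SGC-7901 cells (Homo sapiens) for cytotoxicity, read by sulforhodamine B assay, with a stated time of 72 h; on this read-out higher numbers stand for weaker inhibition and lower numbers for stronger inhibition:
- compound 1 `C=C1C(=O)O[C@@H]2CC(C)=C([C@@H](C)CCCOC(C)=O)[C@@H](OC(=O)COc3cccc(C(C)=O)c3)[C@H]12`: 46100 nM
- compound 2 `C=C1C(=O)O[C@@H]2CC(C)=C([C@@H](C)CCCOC(C)=O)[C@@H](OC(=O)COc3cccc4cccnc34)[C@H]12`: 14300 nM
- compound 3 `C=C1C(=O)O[C@@H]2CC(C)=C([C@@H](C)CCCOC(C)=O)[C@@H](OC(=O)c3cccc(F)c3)[C@H]12`: 12900 nM

Compound 3 sits at the low end of these numbers, level with compound 2, with a gap of a 1.1-fold lower number from compound 2 to compound 3 (0.04 log units; within the scatter). Compound 1 lies clearly higher, and that gap is a 3.6-fold lower number from compound 1 to compound 3 (0.55 log units; beyond the scatter).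

The next compound is compound 4 `C=C1C(=O)O[C@@H]2CC(C)=C([C@@H](C)CCCOC(C)=O)[C@@H](OC(=O)c3ccc(F)cc3)[C@H]12`, which has 4-fluorophenyl in place of 3-fluorophenyl on a carbonyl carbon. The two have the same atoms, joined differently.

Among the compounds with values here, no measured step moves the fluorine around the ring, so the data hold no direct precedent. The nearest evidence is the pair of steps at the same carbonyl carbon, and both of those replace the whole group, a far larger change than this one. Even so, one of them stays within the scatter, a 1.1-fold lower number from compound 2 to compound 3 (0.04 log units; within the scatter), and the other is only modest, a 3.6-fold lower number from compound 1 to compound 3 (0.55 log units; beyond the scatter). A shift of the fluorine alone is therefore not expected to move the number beyond the scatter, and no direction is favoured.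

The expected change is a 1.0-fold higher number from compound 3 to compound 4 (0.00 log units; within the scatter).

For compound 4 the estimated value is 13000 nM, with an expected range of 6000 nM to 28000 nM.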

Compound 4, half-maximal inhibitory concentration: 13600 nM
Estimate against measurement, compound 4: 1.0-fold (0.02 log units) below, within the range that was stated.
By their numbers in this assay, from the lowest: compounds 3, 4 and 2 (each within the scatter of the next); then compound 1.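

In this assay, within the data shown here, the step from 3-fluorophenyl to 4-fluorophenyl on a carbonyl carbon gives a 1.1-fold higher number from compound 3 to compound 4 (0.02 log units; within the scatter); this is the first direct reading of where the fluorine stands on the ring, and the two isomers cannot be told apart in this assay. Set against the larger groups at the same carbonyl carbon, 4-fluorophenyl reads level with ((quinolin-8-yl)oxy)methyl, with a 1.1-fold lower number from compound 2 to compound 4 (0.02 log units; within the scatter), but not with (3-acetylphenoxy)methyl, with a 3.4-fold lower number from compound 1 to compound 4 (0.53 log units; beyond the scatter), so compound 1 alone stands apart, now against three other groups at this place. No evidence in hand bears on this result.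

Open, as far as these compounds go, is whether a plain phenyl, or an amine or a carboxylic acid in place of the fluorine, would read any differently from the two fluorophenyl esters. Also open, from the compounds shown here alone, is whether the gap to compound 1 belongs to the acetyl group or to the oxymethyl link, a question that a phenoxymethyl group without the acetyl would separate.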